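This account rests on a few compounds, and the source may have more. Where it says the series, first, only, none or still open, it means among the compounds named here.

Compound 1 `N#Cc1c(-c2ccc(Cl)cc2)cc(-c2ccc(Cl)cc2)n(CC(O)CCl)c1=O` gives 4.6 ug/mL in a functional assay on MCF7 cells (Homo sapiens) for cytotoxicity, read by sulforhodamine B assay, with a stated time of 48 h; a higher number here means a weaker inhibitor, a lower number a stronger inhibitor. Compound 3 `C=CCn1c(-c2ccc(Cl)cc2)cc(-c2ccc(Cl)cc2)c(C#N)c1=O` gives 19 ug/mL. Compound 2 `N#CCn1c(-c2ccc(Cl)cc2)cc(-c2ccc(Cl)cc2)c(C#N)c1=O` is reported as "not active" (no number reported), with no number given.

Among the two numbers, compound 1 stands lowest, its nearest neighbour being compound 3, reached by a 4.1-fold higher number from compound 1 to compound 3 (0.62 log units; beyond the scatter). Compound 4 `C#CCn1c(-c2ccc(Cl)cc2)cc(-c2ccc(Cl)cc2)c(C#N)c1=O` differs from compound 1 by ethynyl in place of 2-chloro-1-hydroxyethyl on a saturated chain carbon bound to an aromatic nitrogen. Among the compounds with values here, only one measured step bears on this change, namely a 4.1-fold higher number from compound 1 to compound 3 (0.62 log units; beyond the scatter), a modest rise beyond the scatter; compound 2 shows that another small group on the same chain carbon can abolish activity altogether. A rise of similar size is therefore expected, a 3.3-fold higher number from compound 1 to compound 4 (0.51 log units; beyond the scatter), and compound 4 is estimated at 15 ug/mL, within a range from 5 ug/mL to 50 ug/mL.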

Compound 4, half-maximal inhibitory concentration: 16.7 ug/mL
Estimate against measurement, compound 4: 1.1-fold (0.05 log units) below, within the range that was stated.
By their numbers in this assay, from the lowest: compound 1; then compounds 4 and 3 (each within the scatter of the next).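

Propargyl in compound 4 behaves much like the allyl chain of compound 3 in this assay: replacing 3-chloro-2-hydroxypropyl with it also costs activity (a 3.6-fold higher number from compound 1 to compound 4 (0.56 log units; beyond the scatter)), so this loss is not confined to the vinyl end group. Ethynyl and vinyl are not told apart at this place (a 1.1-fold lower number from compound 3 to compound 4 (0.06 log units; within the scatter)), although compound 2, reported as not active, shows that not every small chain matches them. Nothing shown explains either step. As far as these compounds go, it remains open whether the hydroxyl or the chlorine of compound 1 accounts for its lower number, and how a plain propyl chain or an aminopropyl chain would compare.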